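Chloro in place of methyl on compound 1

The source may hold more compounds than are shown below. What is called first, only, known or untested is meant among the compounds shown, and "the series" means these compounds.

Compound 1 `Cc1ccccc1NC(=O)Nc1cccc(CNc2ncnc3ccccc23)c1` stands only as a limit in a functional assay on MGC-803 cells (Homo sapiens) for antiproliferative activity, read by MTT assay; a higher number here means a weaker inhibitor, a lower number a stronger inhibitor: in this assay compound 1 gives > 50000 nM, which is a limit of the assay and not a number (the limit of > 50000 nM in this assay, at which 1 of the 3 values shown sits). Compound 2 `CC(C)(C)c1ccc(NC(=O)Nc2cccc(CNc3ncnc4ccccc34)c2)cc1` gives 7470 nM in this assay, and compound 3 `O=C(Nc1cccc(CNc2ncnc3ccccc23)c1)Nc1ccccc1F` gives 33400 nM. The step of an at least 6.6-fold lower number from compound 1 to compound 2 (0.82 log units; beyond the scatter) is beyond the scatter, whereas an at least 1.4-fold lower number from compound 1 to compound 3 (0.17 log units; that floor lies within the scatter) has a floor that lies within the scatter, and a 4.5-fold higher number from compound 2 to compound 3 (0.65 log units; beyond the scatter) separates the two measured numbers. Compound 4 `O=C(Nc1cccc(CNc2ncnc3ccccc23)c1)Nc1ccccc1Cl` differs from compound 1 by chloro in place of methyl on an aromatic carbon. The step that bears on it most directly is an at least 1.4-fold lower number from compound 1 to compound 3 (0.17 log units; that floor lies within the scatter), in which fluoro replaced the same methyl at the same place. Because that halogen-for-methyl exchange in an at least 1.4-fold lower number from compound 1 to compound 3 (0.17 log units; that floor lies within the scatter) moved the number at most a little, only a small change is expected for compound 4, with a real number below the limit possible but not assured. Compound 4 is expected to give 30000 nM, within 12000 nM to 80000 nM, an expected step of an at least 1.6-fold lower number from compound 1 to compound 4 (0.22 log units; that floor lies within the scatter).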

Compound 4, half-maximal inhibitory concentration: > 50000 nM
Compound 4 was reported as a limit; the forecaster's own chance of this, stated with the estimate: 35%; middle value at least 1.6-fold (0.22 log units) away from the limit.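

Compound 4, like compound 1, sits at a limit of the assay and not at a number in this assay: the limit of > 50000 nM in this assay, at which 2 of the 4 values shown sit.

The step from methyl to chloro on this aromatic carbon, ortho to a large group, cannot be read, and chloro in place of fluoro gives an at least 1.4-fold higher number from compound 3 to compound 4 (0.17 log units; that floor lies within the scatter), so the two halogens cannot be told apart here. For the compounds shown here, the step of an at least 6.6-fold higher number from compound 2 to compound 4 (0.82 log units; beyond the scatter) shows that 2-chlorophenyl, like 2-methylphenyl, stands well apart from the 4-(tert-butyl)phenyl group, and compound 2 is the only compound here whose steps to all the others lie beyond the scatter.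

The compounds shown leave open whether a 4-methylphenyl or a 2-(tert-butyl)phenyl group would match compound 2. They also leave open how far compound 1 and compound 4 really lie from each other.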